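Swapping Amino for Chloro on a Shared Core

This account rests on a few compounds, and the source may have more. Where it says the series, first, only, none or still open, it means among the compounds named here.

Measured compounds in an ADME assay on CCRF-CEM cells (Homo sapiens) for cytotoxicity, with a stated time of 5 days; on this read-out higher numbers stand for weaker inhibition and lower numbers for stronger inhibition:
- compound 1, `[N-]=[N+]=N[C@H]1C[C@H](n2cnc3c(N)nc(F)nc32)O[C@@H]1CO`, gives 30100 nM.
- compound 2, `COc1nc(NC2CC2)c2ncn([C@H]3C[C@H](N=[N+]=[N-])[C@@H](CO)O3)c2n1`, gives only a limit of the assay, > 100000 nM.
- compound 3, `COc1nc(N)c2ncn([C@H]3C[C@H](N=[N+]=[N-])[C@@H](CO)O3)c2n1`, gives only a limit of the assay, > 100000 nM.

Compound 1 is thus the only one of the three with a real number; the other two sit at the limit of > 100000 nM in this assay, at which 2 of the 3 values shown sit. One step can be read: an at least 3.3-fold higher number from compound 1 to compound 3 (0.52 log units; beyond the scatter), so methoxy in place of fluoro weakens the effect. The step that the two limits leave unreadable from compound 2 to compound 3 cannot be sized.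

Compound 4, `[N-]=[N+]=N[C@H]1C[C@H](n2cnc3c(Cl)nc(F)nc32)O[C@@H]1CO`, differs from compound 1 by chloro in place of amino on an aromatic carbon. For the measured compounds named here, none of the measured steps touches this group, so no measured step bears directly on the change, and the direction can only be guessed. A change that removes the hydrogen-bond donor and acceptor is expected to leave compound 4 near or somewhat weaker than compound 1, with the outcome expected to be a 2.0-fold higher number from compound 1 to compound 4 (0.30 log units; within the scatter). Compound 4 is estimated at 60000 nM, in the range 10000 nM to 150000 nM.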

Compound 4, half-maximal inhibitory concentration: 13300 nM
For compound 4 the middle estimate is 4.5-fold (0.65 log units) above the measured one; measured number inside the range.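

For the compounds shown here, this is the first readable step at the place of the amino group, next to the ring nitrogen, and it shows that this position also moves the read-out: in this assay, chloro in place of amino gives a 2.3-fold lower number from compound 1 to compound 4 (0.35 log units; beyond the scatter). Chloro carries none of the hydrogen-bond donors or acceptors counted on the amino group, yet the number falls, so losing them does not weaken the effect in this pair. Nothing shown here explains why the number moves in this direction.

A single pair cannot show whether the stronger effect is particular to chloro or would also appear with another group at this place, such as bromo or methyl. It also leaves open whether the same swap would act alike with methoxy in place of the fluoro group.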